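The source may hold more compounds than are shown below. What is called first, only, known or untested is meant among the compounds shown, and "the series" means these compounds.

Measured in an assay on isolated protein for binding affinity to adenosine receptor A1 (Bos taurus); on this read-out higher numbers stand for weaker inhibition and lower numbers for stronger inhibition:

Compound 1, `CCCCCCNc1nc(-c2ccccc2)nc2c1nnn2Cc1ccccc1`, gives 13200000 nM.
Compound 2, `c1ccc(Cn2nnc3c(NC4CCCC4)nc(-c4ccccc4)nc32)cc1`, gives 11000000 nM.
Compound 3, `OCCCNc1nc(-c2ccccc2)nc2c1nnn2Cc1ccccc1`, gives 21400000 nM.

Compound 3 carries the highest of the three numbers in this assay, but the gaps that separate it from the others are small: a 1.6-fold higher number from compound 1 to compound 3 (0.21 log units; within the scatter) and a 1.9-fold higher number from compound 2 to compound 3 (0.29 log units; within the scatter). The step between compound 1 and compound 2 is likewise slight, a 1.2-fold lower number from compound 1 to compound 2 (0.08 log units; within the scatter). All three compounds therefore sit in the same band, and none can be called weaker or stronger than another.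

Compound 4, `O[C@H]1CCCC[C@@H]1Nc1nc(-c2ccccc2)nc2c1nnn2Cc1ccccc1`, is the next compound in this series. Its change from compound 3 is 2-hydroxycyclohexyl in place of 3-hydroxypropyl on a nitrogen on an aromatic ring. Two of the measured steps bear on this change: the replacement of a ring by the 3-hydroxypropyl chain, a 1.9-fold higher number from compound 2 to compound 3 (0.29 log units; within the scatter), and the exchange of a hydroxy for a propyl on that chain, a 1.6-fold higher number from compound 1 to compound 3 (0.21 log units; within the scatter). Neither moved the number beyond the scatter, and the change to compound 4 combines a ring with a hydroxy, both already seen to do little. The expected step is thus a 1.4-fold lower number from compound 3 to compound 4 (0.15 log units; within the scatter), no larger than the scatter. Compound 4 is therefore estimated at 15000000 nM in this assay, within the range 5000000 nM to 45000000 nM.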

Compound 4, inhibition constant: 10300000 nM
Estimate against measurement, compound 4: 1.5-fold (0.16 log units) above; measured number inside the range.
By their numbers in this assay, from the lowest: compounds 4, 2, 1 and 3 (each within the scatter of the next, the first and the last beyond it).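

In this assay, for the compounds shown here, 2-hydroxycyclohexyl in place of 3-hydroxypropyl on a nitrogen on an aromatic ring gives the first step to pass the scatter (a 2.1-fold lower number from compound 3 to compound 4 (0.32 log units; beyond the scatter)), although it is only a modest one. The other two new steps stay within the scatter, with 2-hydroxycyclohexyl in place of cyclopentyl (a 1.1-fold lower number from compound 2 to compound 4 (0.03 log units; within the scatter)) and in place of hexyl (a 1.3-fold lower number from compound 1 to compound 4 (0.11 log units; within the scatter)), so at this position a hydroxy-bearing six-membered ring cannot be told apart from either of the groups that lack a hydroxy, and only its comparison with the 3-hydroxypropyl chain stands out. Nothing available explains why this one exchange passes the scatter while the others do not.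

The compounds shown leave open what part the hydroxy plays on the ring, since the comparison that would isolate it, plain cyclohexyl against 2-hydroxycyclohexyl, is absent here, and what part the two defined stereocentres play. They also leave open whether an amine or a carboxylic acid in place of that hydroxy would move the number out of this narrow band.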